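A few compounds are considered here, and "the series" means these few. Any claim that something is new, unique, unknown or untested is made for them only; others in the source may bear on it.

Compound 2 `CCN1CCN(c2cccc3c2C[C@H](CN(C)[C@H]2CCCc4cccnc42)NC3)CC1` gives 18.8% in an ADME assay on microsomes from liver (Mus musculus) for metabolic stability, read by LC-MS, with a stated time of 10 min (a higher number here means that more of the compound is left, a lower number that less of the compound is left), the lowest of the three numbers measured: compound 3 `CN(C[C@H]1Cc2c(cccc2N2CCN(c3ncccn3)CC2)CN1)[C@H]1CCCc2cccnc21` gives 35.1%, and compound 1 `C[C@@H]1CN(c2cccc3c2C[C@H](CN(C)[C@H]2CCCc4cccnc42)NC3)C[C@H](C)N1` gives 85.6%. Compound 4 `CN(C[C@H]1Cc2c(cccc2N2CCNC(C)(C)C2)CN1)[C@H]1CCCc2cccnc21` differs from compound 2 in one place: 3,3-dimethylpiperazin-1-yl in place of 4-ethylpiperazin-1-yl on an aromatic carbon. For the measured compounds named here, two measured steps bear on this change. The first, a number 66.8 percentage points lower from compound 1 to compound 2 (beyond the scatter), shows that swapping a 3,5-dimethylpiperazin-1-yl for 4-ethylpiperazin-1-yl cost a great deal; the second, a number 16.3 percentage points higher from compound 2 to compound 3 (beyond the scatter), shows a smaller gain when ethyl gave way to pyrimidin-2-yl. A large rise in this assay is therefore expected for compound 4, because a number 66.8 percentage points lower from compound 1 to compound 2 (beyond the scatter) ran the other way on a closely related exchange. Compound 4 is estimated at 68%, with a likely range from 42% to 88%. That estimate means an expected step of a number 49.2 percentage points higher from compound 2 to compound 4 (beyond the scatter).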

Compound 4, percent of the compound remaining: 44%
Compound 4: the middle estimate sits 24 percentage points above what was measured; measured number inside the range.
By their numbers in this assay, from the lowest: compound 2; then compounds 3 and 4 (each within the scatter of the next); then compound 1.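

In this assay, the two dimethyl isomers do not behave alike: 3,3-dimethylpiperazin-1-yl in place of 3,5-dimethylpiperazin-1-yl gives a number 41.6 percentage points lower from compound 1 to compound 4 (beyond the scatter), so where the two methyl groups sit on the piperazine matters, not only that they are present. Against 4-ethylpiperazin-1-yl, which has the same atoms joined differently, the 3,3-dimethyl group still gives a number 25.2 percentage points higher from compound 2 to compound 4 (beyond the scatter), so atom content alone does not set the number. Nothing measured here explains either step. Open, going by these compounds, is how a single methyl, as in 3-methylpiperazin-1-yl, would compare, and whether a morpholine ring could replace the piperazine.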